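The source may hold more compounds than are shown below. What is called first, only, known or untested is meant among the compounds shown, and "the series" means these compounds.

Within the data shown here, in an ADME assay on microsomes from liver (Homo sapiens) for metabolic stability, read by LC-MS, using NADPH, with a stated time of 30 min, tested at 1 uM (a higher number here means faster removal of the compound, a lower number slower removal), compound 1 `CC(C)c1noc(N2CCC(Oc3cc(N4CCc5cc(N6CCCNS6(=O)=O)ccc54)ncn3)CC2)n1` gives 79 mL.min-1.g-1 and compound 2 `CC(C)c1noc(N2CCC(Oc3cc(N4CCc5cc(N6CCCS6(=O)=O)ccc54)ncn3)CC2)n1` gives 18 mL.min-1.g-1, the lower of the two numbers so far. Compound 3 `CC(=O)N(C)c1ccc2c(c1)CCN2c1cc(OC2CCN(c3nc(C(C)C)no3)CC2)ncn1` differs from compound 2 at one place: a group of 5 heavy atoms (3 carbon, 1 nitrogen, 1 oxygen; no ring) in place of a group of 7 heavy atoms (3 carbon, 1 nitrogen, 2 oxygen, 1 sulfur; one five-membered non-aromatic ring with 2 hetero atoms), on an aromatic carbon. Among the measured compounds shown here, the only measured step at this place, a 4.4-fold lower number from compound 1 to compound 2 (0.64 log units; beyond the scatter), was modest and beyond the scatter. It exchanged a different ring, so it shows how large a change here can be but not its direction for a group with no ring. The expected step in this assay is a small rise, a 1.7-fold higher number from compound 2 to compound 3 (0.22 log units; within the scatter), probably within the scatter. Compound 3 is estimated at 30 mL.min-1.g-1, with an expected range of 12 mL.min-1.g-1 to 75 mL.min-1.g-1.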

Compound 3, intrinsic clearance in microsomes: 173 mL.min-1.g-1
The estimate for compound 3 lay 5.8-fold (0.76 log units) below the measured number; the whole stated range lies below it.
By their numbers in this assay, from the lowest: compound 2; then compound 1; then compound 3.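

In this assay, among these compounds, the acetyl(methyl)amino group gives the highest number at this position so far, above the five-membered ring group (a 9.6-fold higher number from compound 2 to compound 3 (0.98 log units; beyond the scatter)) and above the six-membered ring group (a 2.2-fold higher number from compound 1 to compound 3 (0.34 log units; beyond the scatter)). The position therefore tolerates no simple reading from the ring exchange alone: a group with no ring stands above both ring groups, not between them. No measured evidence bears on the reason for this order.

From the compounds shown here alone, it remains open whether the ring's removal or the acetyl group sets this number. A methanesulfonyl(methyl)amino or a dimethylamino group at this place would separate the two.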